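The compounds below may be only part of what the source reports. "The series", "measured", "known", "first", "only" and "open" are said of these compounds alone.

Measured so far:
compound 1 `O=C(O)CN1C(=O)[C@@H](NC(=O)[C@@H](CS)Cc2ccccc2)CCc2ccccc21` – 2.1 nM
compound 2 `O=C(O)CN1C(=O)[C@@H](NC(=O)[C@@H](CS)Cc2ccccc2)COc2ccccc21` – 0.6 nM

In an assay on isolated protein for inhibition of Neprilysin (Homo sapiens) (on this read-out lower numbers stand for stronger inhibition and higher numbers for weaker inhibition), compound 1 gives 2.1 nM and stands at the higher of the two numbers; compound 2 gives 0.6 nM, a lower number, and the gap between the two lies beyond the scatter. Compound 3 `O=C(O)CCN1C(=O)[C@@H](NC(=O)[C@@H](CS)Cc2ccccc2)CCc2ccccc21` has not yet been measured in this assay. Against compound 1 the change is carboxymethyl in place of carboxy on a saturated chain carbon bound to an amide-type nitrogen in a ring; cut one bond further out, the same difference reads carboxymethyl to 2-carboxyethyl. Within the data shown here, no measured pair carries this change, so the expectation rests on compound 1 alone. The expected step is a 3.3-fold higher number from compound 1 to compound 3 (0.52 log units; beyond the scatter), a moderate weakening rather than none. For compound 3 the estimate in this assay is 7 nM, with a range of 2 nM to 25 nM.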

Compound 3, half-maximal inhibitory concentration: 1.7 nM
Estimate against measurement, compound 3: 4.1-fold (0.61 log units) above; measured number outside the range, below it.
By their numbers in this assay, from the lowest: compound 2; then compounds 3 and 1 (each within the scatter of the next).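

In this assay, the change from carboxymethyl to 2-carboxyethyl gives a 1.2-fold lower number from compound 1 to compound 3 (0.09 log units; within the scatter), so the two compounds cannot be told apart on this read-out. On the core of compound 1, the carboxylic acid on this chain therefore accepts this extension without a change beyond the scatter, which a single compound could not show. No supporting data are available to explain this result.

From the compounds shown here alone, whether the same extension is tolerated on the core of compound 2 remains open. Also open, going by these compounds, is how far the tolerance reaches: a longer chain such as 3-carboxypropyl, or an amine or a primary amide in place of the carboxylic acid, could either keep the number or lose it.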